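A few compounds are considered here, and "the series" means these few. Any claim that something is new, unique, unknown or untested is made for them only; others in the source may bear on it.

The measured compounds, with their values in an assay on MDA-MB-231 cells for binding affinity to C-X-C chemokine receptor type 4 (Homo sapiens), read by immunofluorescence and microscopy, with stated times of 10 min and 30 min; on this read-out higher numbers stand for an effect only at larger amounts of compound and lower numbers for an effect already at smaller amounts:

compound 1, `Cc1ccc(S(=O)(=O)NCc2ccc(CNC(=O)c3c(Cl)cc(Cl)cc3Cl)cc2)cc1`: 10 nM
compound 2, `O=C(NCc1ccc(CNS(=O)(=O)c2ccccc2)cc1)c1c(Cl)cc(Cl)cc1Cl`: 10 nM
compound 3, `Cc1ccc(C(=O)NCc2ccc(CNS(=O)(=O)c3ccccc3)cc2)cc1`: 100 nM

Compound 1 stands level with compound 2 at the digits shown, and together they give the lowest numbers of the three; the step of no change at the digits printed from compound 1 to compound 2 (within the scatter), a hydrogen in place of a methyl on an aromatic carbon, leaves the number unchanged. For the measured compounds named here, the only step beyond the scatter is a 10-fold higher number from compound 2 to compound 3 (1.00 log units; beyond the scatter), where the ring on the carbonyl carbon was exchanged, so that is the part of the molecule where the numbers have moved.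

Compound 4, `Cc1ccc(S(=O)(=O)NCc2ccc(CNC(=O)c3ccccc3Cl)cc2)cc1`, differs from compound 1 by 2-chlorophenyl in place of 2,4,6-trichlorophenyl on a carbonyl carbon. This change sits on the same carbonyl carbon as the step of a 10-fold higher number from compound 2 to compound 3 (1.00 log units; beyond the scatter). There, all three chlorines left and a modest rise followed; here two chlorines leave and one stays, so a rise is expected, but a smaller one, within the scatter or a little beyond it. Compound 4 is therefore expected to give 30 nM, with a likely range from 10 nM to 100 nM. The expected step is a 3.0-fold higher number from compound 1 to compound 4 (0.48 log units; beyond the scatter).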

Compound 4, effective concentration (reported as EC, without a stated level of effect): 10 nM
Compound 4: middle estimate off by 3.0-fold (0.48 log units), on the high side, within the range that was stated.
By their numbers in this assay, from the lowest: compounds 1, 2 and 4 (each within the scatter of the next); then compound 3.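

2-chlorophenyl in place of 2,4,6-trichlorophenyl on the carbonyl carbon gives no change at the digits printed from compound 1 to compound 4 (within the scatter) in this assay. The full set of three chlorines is not needed to hold the number at this position. The earlier step at this same place, a 10-fold higher number from compound 2 to compound 3 (1.00 log units; beyond the scatter), had suggested only that the position matters; the new step shows that a ring with a single chlorine still sits level with the trichlorinated one, while the 4-methylphenyl ring of compound 3 does not. Nothing available explains why these rings differ.

As far as these compounds go, whether the one remaining chlorine is needed stays open, since plain phenyl on this carbonyl carbon would be the direct test. How a ring carrying an amine or a carboxylic acid would behave at this position is also unknown.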